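A Biaryl Swap in a Cytotoxicity Screen

This account rests on a few compounds, and the source may have more. Where it says the series, first, only, none or still open, it means among the compounds named here.

Compound 1 `CCOC(=O)CCCCCOc1cccc(CN(C(=O)c2ccc(-c3cccc(C(C)=O)c3)cc2)C(C)C)c1` and compound 2 `CCOC(=O)CCCCCOc1cccc(CN(C(=O)c2ccc(-c3ccc(C(C)=O)s3)cc2)C(C)C)c1` share the same core and differ only in the ring attached to it. In an ADME assay on BJ cells (Homo sapiens) for cytotoxicity, read by CellTiter-Glo and resazurin assay, with a stated time of 72 h (a higher number here means that more compound is needed for the effect, a lower number that less compound is needed), compound 1 reaches only the limit of the test, > 26000 nM. Compound 2 likewise gives only a limit, > 26000 nM. The exchange of 3-acetylphenyl for 5-acetylthiophen-2-yl on an aromatic carbon therefore yields a step that the two limits leave unreadable from compound 1 to compound 2. Compound 2 thus stands at the ceiling of what this assay can read, the same place as the limit of > 26000 nM in this assay, at which 2 of the 2 values shown sit. Compound 3 `CCOC(=O)CCCCCOc1cccc(CN(C(=O)c2ccc(-c3cccc(-c4nnc(C)o4)c3)cc2)C(C)C)c1` carries the change (3-(5-methyl-1,3,4-oxadiazol-2-yl)phenyl in place of 5-acetylthiophen-2-yl on an aromatic carbon). Within the data shown here, the single measured step is itself unreadable, so it offers no direction for this change. Both known values sit at the limit, so compound 3 is expected to give 50000 nM, with a range from 20000 nM to 150000 nM. The expected step that the limit leaves unreadable from compound 2 to compound 3 is therefore nothing beyond the scatter.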

Compound 3, half-maximal effective concentration: > 26000 nM
Compound 3 was reported as a limit; the forecaster's own chance of this, stated with the estimate: 80%; the middle value lies beyond the limit too.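

Compound 3 gives only a limit, > 26000 nM, so the steps linking compound 1, compound 2 and compound 3 cannot be read. The compounds shown leave open what concentration of each would produce the effect in this assay, and whether these ring exchanges change it at all.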